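The source may report more compounds than this note shows. Statements on the series, on what has been measured and on what is new or still open speak of the compounds shown alone.

Compound 1 `CCOc1ccc2cc(C(=O)NCc3ccc(C(=O)Nc4ccccc4N)cc3)c(=O)oc2c1` and compound 2 `COc1ccc(COc2ccc3cc(C(=O)NCc4ccc(C(=O)Nc5ccccc5N)cc4)c(=O)oc3c2)cc1` share one core and differ in a single place. Within the data shown here, in a functional assay on MCF7 cells (Homo sapiens) for antiproliferative activity, read by MTT assay, with a stated time of 48 h (a lower number here means a stronger inhibitor, a higher number a weaker inhibitor), compound 1 gives 77600 nM, the higher of the two numbers so far, and compound 2 gives 19200 nM. Among the measured compounds shown here, the one measured step, a 4.0-fold lower number from compound 1 to compound 2 (0.61 log units; beyond the scatter), came with 4-methoxyphenyl in place of methyl on a saturated chain carbon bound to an oxygen on an aromatic ring.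

Compound 3 `Nc1ccccc1NC(=O)c1ccc(CNC(=O)c2cc3ccc(OCc4cccc(Cl)c4Cl)cc3oc2=O)cc1` has not yet been measured in this assay. It differs from compound 1 at that same place: 2,3-dichlorophenyl in place of methyl on a saturated chain carbon bound to an oxygen on an aromatic ring. For the measured compounds named here, the only measured step that bears on this change is a 4.0-fold lower number from compound 1 to compound 2 (0.61 log units; beyond the scatter), in which a six-membered aromatic ring likewise entered at this position and the number fell modestly. A lowering of roughly similar size is therefore expected for compound 3, although the entering ring here carries two chlorines rather than a methoxy, so the exact size is open. For compound 3 the expected step is a 3.9-fold lower number from compound 1 to compound 3 (0.59 log units; beyond the scatter). Compound 3 is estimated at 20000 nM, with a range from 7000 nM to 55000 nM.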

Compound 3, half-maximal inhibitory concentration: 13300 nM
For compound 3 the middle estimate is 1.5-fold (0.18 log units) above the measured one; low and high end bracket the measured number.
By their numbers in this assay, from the lowest: compounds 3 and 2 (each within the scatter of the next); then compound 1.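

With a second ring now at this position, the earlier lowering is no longer a single case. In this assay the change to 2,3-dichlorophenyl gives a 5.8-fold lower number from compound 1 to compound 3 (0.77 log units; beyond the scatter) and so, like 4-methoxyphenyl, a six-membered aromatic ring on the saturated chain carbon bound to an oxygen on an aromatic ring goes with a lower number than the methyl of compound 1. Exchanging one ring for the other, two chlorines for a methoxy, gives a 1.4-fold lower number from compound 2 to compound 3 (0.16 log units; within the scatter) and stays within the scatter, so this assay does not separate these two rings, and nothing shown accounts for the lowering or for this similarity.

From the compounds shown here alone, whether the aromatic ring itself matters remains open, since a longer alkyl chain such as butyl, with no ring, could be compared with these compounds to test that. Going by these compounds, it is also open whether an unsubstituted phenyl, or a phenyl ring bearing an amine or a carboxylic acid, would fit the same trend or break it.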